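Triazole substituent change on the shared lactone core

A few compounds are considered here, and "the series" means these few. Any claim that something is new, unique, unknown or untested is made for them only; others in the source may bear on it.

Notes on the series in a functional assay on MCF7 cells (Homo sapiens) for antiproliferative activity, read by MTT assay, with a stated time of 72 h; a higher number here means a weaker inhibitor, a lower number a stronger inhibitor. Compound 1 `CCCCc1cn(C[C@H](O)[C@H]2OC(=O)C(OCc3ccccc3)=C2OCc2ccccc2)nn1` gives 7910 nM. Compound 2 `O=C1O[C@H]([C@@H](O)Cn2cc(C3CC3)nn2)C(OCc2ccccc2)=C1OCc1ccccc1` gives 25900 nM, and compound 3 `O=C1O[C@H]([C@@H](O)Cn2cc(CNS(=O)(=O)c3ccc(Cl)cc3)nn2)C(OCc2ccccc2)=C1OCc1ccccc1` gives 4170 nM, the lowest of the three numbers. The step of a 3.3-fold higher number from compound 1 to compound 2 (0.52 log units; beyond the scatter) lies beyond the scatter, whereas the step of a 1.9-fold lower number from compound 1 to compound 3 (0.28 log units; within the scatter) does not; the step of a 6.2-fold lower number from compound 2 to compound 3 (0.79 log units; beyond the scatter) is again beyond it. Compound 3 therefore stands nearest to compound 1 and furthest from compound 2.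

Compound 4 `O=C1O[C@H]([C@@H](O)Cn2cc(-c3cc(F)cc(F)c3)nn2)C(OCc2ccccc2)=C1OCc1ccccc1` differs from compound 3 in one place: 3,5-difluorophenyl in place of (((4-chlorophenyl)sulfonyl)amino)methyl on an aromatic carbon. For the measured compounds named here, no measured step places an aryl group on that carbon, so only indirect steps bear on it. The step of a 6.2-fold lower number from compound 2 to compound 3 (0.79 log units; beyond the scatter) and the step of a 1.9-fold lower number from compound 1 to compound 3 (0.28 log units; within the scatter) both run toward a lower number when the (((4-chlorophenyl)sulfonyl)amino)methyl group is present, once modestly and once within the scatter. Taking that group away is thus expected to give a modest rise, a 1.9-fold higher number from compound 3 to compound 4 (0.28 log units; within the scatter). Compound 4 is estimated at 8000 nM, with a range from 2500 nM to 25000 nM.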

Compound 4, half-maximal inhibitory concentration: 27700 nM
Compound 4: middle estimate off by 3.5-fold (0.54 log units), on the low side; measured number outside the range, above it.
By their numbers in this assay, from the lowest: compounds 3 and 1 (each within the scatter of the next); then compounds 2 and 4 (each within the scatter of the next).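

A 3,5-difluorophenyl group set directly on this aromatic carbon does not reproduce the result of compound 3, although the leaving and entering groups each hold one six-membered aromatic ring of carbon only: the change gives a 6.6-fold higher number from compound 3 to compound 4 (0.82 log units; beyond the scatter). Aryl and cyclopropyl cannot be told apart at this place, with a 1.1-fold higher number from compound 2 to compound 4 (0.03 log units; within the scatter), whereas the comparison with the butyl compound gives a 3.5-fold higher number from compound 1 to compound 4 (0.54 log units; beyond the scatter) and so places compound 4 with compound 2 on the high side of compound 1. No evidence is available to explain these steps.

Open, from the compounds shown here alone, is which part of the (((4-chlorophenyl)sulfonyl)amino)methyl group carries the difference from compound 4. Also open, going by these compounds, is how a plain phenyl, a benzyl group or a longer chain ending in an amine would compare at this carbon.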